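Benzoylguanidine series: the substituent on the aromatic carbon

This account rests on a few compounds, and the source may have more. Where it says the series, first, only, none or still open, it means among the compounds named here.

Measured so far:
compound 1, `CS(=O)(=O)c1cc(C(=O)N=C(N)N)ccc1-n1ccnc1`, in a functional assay for inhibition of sodium/hydrogen exchanger (Oryctolagus cuniculus) (a higher number here means a weaker inhibitor, a lower number a stronger inhibitor), compound 1 gives 150 nM
compound 2, `CS(=O)(=O)c1cc(C(=O)N=C(N)N)ccc1C1CCCCC1`, in this assay compound 2 gives 340 nM

Within the data shown here, compound 2 stands at the highest number of the two; the only measured step is a 2.3-fold higher number from compound 1 to compound 2 (0.36 log units; beyond the scatter), and compound 1 is the nearest neighbour of compound 2.

Compound 3, `CS(=O)(=O)c1cc(C(=O)N=C(N)N)ccc1Br`, is not yet measured. It differs from compound 2 in one place: bromo in place of cyclohexyl on an aromatic carbon. Among the measured compounds shown here, no measured step covers a bromo group at this carbon; the single step available, from the group of compound 1 to that of compound 2, changes the same position and was modest in size. The change to compound 3 removes a ring and leaves a single heavy atom in its place, which the data so far do not cover, so the expectation rests on a loose analogy only. For compound 3 the expected step in this assay is a 1.5-fold higher number from compound 2 to compound 3 (0.17 log units; within the scatter), a small rise that may well fall within the scatter. The estimate for compound 3 in this assay is 500 nM, with a range of 150 nM to 2000 nM.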

Compound 3, half-maximal inhibitory concentration: 180 nM
Compound 3: middle estimate off by 2.8-fold (0.44 log units), on the high side; the measured number falls inside the stated range.
By their numbers in this assay, from the lowest: compounds 1, 3 and 2 (each within the scatter of the next, the first and the last beyond it).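

In this assay, replacing the cyclohexyl ring with a bromo group, which has one heavy atom and no ring, gives a 1.9-fold lower number from compound 2 to compound 3 (0.28 log units; within the scatter), and replacing the 1H-imidazol-1-yl group with bromo gives a 1.2-fold higher number from compound 1 to compound 3 (0.08 log units; within the scatter). Neither step separates compound 3 from the compound it is paired with, so among these three compounds a ring on this aromatic carbon is not needed for a number in this range, and heavy-atom count does not track the read-out. Compound 3 sits within the scatter of both neighbours even though compound 1 and compound 2 lie beyond the scatter of each other, and no supporting evidence bears on why these three groups read as they do.

From the compounds shown here alone, the span across this position remains narrow, so it is open whether an amine such as dimethylamino, a carboxylic acid, a methoxy group or a longer alkyl chain on this carbon would fall within it or well outside it. Also open, going by these compounds, is how a smaller halogen such as chloro or fluoro, or plain hydrogen, would compare with bromo on the shared core.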